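Trimming the ring on the aminoquinoline ether side chain

The source may report more compounds than this note shows. Statements on the series, on what has been measured and on what is new or still open speak of the compounds shown alone.

The measured compounds:
Compound 1 `COCC(C)Oc1cccc2ccc(N)nc12` gives 606 nM in an assay on cells with melanin-concentrating hormone receptor 1 (Homo sapiens) as the target, read by radioligand binding; a lower number here means a stronger inhibitor, a higher number a weaker inhibitor.
Compound 2 `CCOCCOc1cccc2ccc(N)nc12` reaches only a limit of the assay, > 2000 nM.
Compound 3 `Nc1ccc2cccc(OCC3CCCC3)c2n1` gives 53 nM.
Compound 4 `CC1CC1COc1cccc2ccc(N)nc12` has not yet been measured.

Of the numbers shown, compound 3 stands lowest: compound 1 sits well above it, an 11-fold lower number from compound 1 to compound 3 (1.06 log units; beyond the scatter), and compound 2 gives only a limit, (the limit of > 2000 nM in this assay, at which 1 of the 3 values shown sits). The step from compound 3 to compound 4 is 2-methylcyclopropyl in place of cyclopentyl on a saturated chain carbon bound to an oxygen on an aromatic ring. The measured steps that bear on it both end at compound 3 and both replace an oxygen-containing chain by a carbocycle: an 11-fold lower number from compound 1 to compound 3 (1.06 log units; beyond the scatter) and an at least 37-fold lower number from compound 2 to compound 3 (1.57 log units; beyond the scatter). They show that the cyclopentylmethyl ether gives a much lower number than either ether-bearing chain, but no measured step varies the size of a carbocycle, so the cost of shrinking the five-membered ring to a 2-methylcyclopropyl is not directly shown. Since compound 4 keeps a purely carbon ring rather than returning to an ether chain, only a modest rise is expected; the estimate for compound 4 is 110 nM, within 35 nM to 400 nM. This estimate means an expected step of a 2.1-fold higher number from compound 3 to compound 4 (0.32 log units; beyond the scatter).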

Compound 4, half-maximal inhibitory concentration: 1640 nM
Compound 4: middle estimate off by 15-fold (1.17 log units), on the low side, outside the stated range (above it).
By their numbers in this assay, from the lowest: compound 3; then compound 1; then compound 4. At a limit, above all of these: compound 2.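

In this assay, among these compounds, a ring of carbon only is not enough to hold the low number at this place: a 31-fold higher number from compound 3 to compound 4 (1.49 log units; beyond the scatter), so what the earlier steps showed for the cyclopentylmethyl ether does not carry over to the (2-methylcyclopropyl)methyl ether, which has a three-membered ring in place of the five-membered one. The new compound also reverses the earlier contrast between carbocycle and oxygen-containing chain, since a 2.7-fold higher number from compound 1 to compound 4 (0.43 log units; beyond the scatter), leaving the 1-(methoxymethyl)ethyl chain with the lower number of the pair. Compound 2 gives only a limit of the assay, and against that limit an at least 1.2-fold lower number from compound 2 to compound 4 (0.08 log units; that floor lies within the scatter), so no order between the two can be read: the limit of > 2000 nM in this assay, at which 1 of the 4 values shown sits.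

This change alters ring size and brings in a methyl group at once, so the compounds shown do not separate the two, and a plain cyclopropyl, a cyclobutyl or a cyclohexyl on the same saturated chain carbon would be needed to do so. They also leave open how a carbocycle bearing an amine or a carboxylic acid would read in this assay.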